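Shifting a chlorine on a phenyl ring: two matched pairs

The compounds below may be only part of what the source reports. "The series", "measured", "known", "first", "only" and "open" are said of these compounds alone.

Compound 1 `O=c1[nH]cc(S(=O)(=O)Nc2ccccc2-c2cn(-c3cccc(Cl)c3)nn2)c(=O)[nH]1` and compound 2 `O=c1[nH]cc(S(=O)(=O)Nc2ccccc2-c2cn(-c3ccc(Cl)cc3)nn2)c(=O)[nH]1` share one core, while compound 3 `O=c1[nH]cc(S(=O)(=O)Nc2cccc(-c3cn(-c4cccc(Cl)c4)nn3)c2)c(=O)[nH]1` and compound 4 `O=c1[nH]cc(S(=O)(=O)Nc2cccc(-c3cn(-c4ccc(Cl)cc4)nn3)c2)c(=O)[nH]1` share another; how the two cores differ is not broken down here. In a functional assay on HepG2 cells (Homo sapiens) for antiproliferative activity, read by MTT assay, with a stated time of 24 h (a higher number here means a weaker inhibitor, a lower number a stronger inhibitor), compound 1 gives 2460 nM, and compound 2 gives 1840 nM. The change between them, (4-chlorophenyl in place of 3-chlorophenyl on an aromatic nitrogen), occurs twice among these compounds and made a step of a 1.3-fold lower number from compound 1 to compound 2 (0.13 log units; within the scatter). Compound 3 gives 4200 nM in this assay. Compound 4 carries the same change on the other core, (4-chlorophenyl in place of 3-chlorophenyl on an aromatic nitrogen), and the step from compound 3 to compound 4 is expected to be about a 1.3-fold lower number from compound 3 to compound 4 (0.12 log units; within the scatter), resting on the near-flat step of a 1.3-fold lower number from compound 1 to compound 2 (0.13 log units; within the scatter). Compound 4 is therefore estimated at 3200 nM, in a range from 1500 nM to 7000 nM.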

Compound 4, half-maximal inhibitory concentration: 1960 nM
The estimate for compound 4 lay 1.6-fold (0.21 log units) above the measured number, and the stated range covers the measured number.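

On the core of compound 3, the change gave a 2.1-fold lower number from compound 3 to compound 4 (0.33 log units; beyond the scatter) in this assay. Among the compounds shown here, one step lies within the scatter and the other beyond it, but the two cannot be told apart, so the change carried over between these two cores without a measurable difference: the same change on two cores in this assay, a 1.3-fold lower number (0.13 log units; within the scatter) from compound 1 to compound 2 and a 2.1-fold lower number (0.33 log units; beyond the scatter) from compound 3 to compound 4, 1.6-fold (0.20 log units) apart, within the scatter of two such steps This is only two matched pairs in one cell assay, so it does not show that the change would carry over to any other core, nor does it explain why the numbers move.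

The compounds shown leave open how a fluorine, a methoxy group or a nitrile would compare with the chlorine on the phenyl ring. They also leave open what a plain phenyl ring with no chlorine would give on either core.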